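Swapping the amide on a pyrazole core: rat half-life

The source may hold more compounds than are shown below. What is called first, only, known or untested is meant among the compounds shown, and "the series" means these compounds.

Measured so far:
Compound 1, `Cc1cc(C(=O)NCc2ccccc2)nn1Cc1cc(Cl)ccc1OCc1ccccc1`, in an in vivo ADME assay on the whole organism for metabolic stability, with Rattus norvegicus as the target (a higher number here means that the compound lasts longer, a lower number that the compound disappears faster), gives 4.6 h.
Compound 2, `Cc1cc(C(=O)NCc2ccccn2)nn1Cc1cc(Cl)ccc1OCc1ccccc1`, in this assay gives 1.3 h.

Among the measured compounds shown here, compound 2 holds the lower of the two numbers in this assay; the only measured step, a 3.5-fold lower number from compound 1 to compound 2 (0.55 log units; beyond the scatter), lies beyond the scatter and separates it from compound 1. Compound 3, `Cc1cc(NC(=O)C2CCOCC2)nn1Cc1cc(Cl)ccc1OCc1ccccc1`, arises from compound 2 by ((oxan-4-yl)carbonyl)amino in place of ((pyridin-2-yl)methyl)carbamoyl on an aromatic carbon. For the measured compounds named here, this change does not resemble the single measured step, which only swaps one aromatic ring for another at the end of the side chain; here the whole amide is rebuilt in the opposite sense, with a saturated ring in place of an aromatic one. Going by the values given here, no measured step therefore bears directly on it, and the direction is open. The estimate for compound 3 in this assay is 2.5 h, within a range of 0.8 h to 8 h. This corresponds to an expected step of a 1.9-fold higher number from compound 2 to compound 3 (0.28 log units; within the scatter), which reflects the spread seen between compound 1 and compound 2 rather than a firm prediction.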

Compound 3, half-life: 1 h
For compound 3 the middle estimate is 2.5-fold (0.40 log units) above the measured one; measured number inside the range.
By their numbers in this assay, from the lowest: compounds 3 and 2 (each within the scatter of the next); then compound 1.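

The place on the shared core that carries the side chain can hold more than one kind of amide without the number settling on a single value. In this assay, ((oxan-4-yl)carbonyl)amino in place of ((pyridin-2-yl)methyl)carbamoyl gives a 1.3-fold lower number from compound 2 to compound 3 (0.11 log units; within the scatter) and so leaves compound 2 and compound 3 level, while the same group in place of benzylcarbamoyl gives a 4.6-fold lower number from compound 1 to compound 3 (0.66 log units; beyond the scatter) and leaves compound 1 clearly the longest-lasting of the three. Nothing measured here explains these numbers.

Between compound 2 and compound 3 the direction of the amide and the ring at its end change together, so their separate contributions remain unknown. On these data alone, a benzoylamino group on the same aromatic carbon would keep the direction of compound 3 with an aromatic end ring, and where it falls remains open.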